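Swapping a Bromophenyl Group for a Dihydroxyphenyl Group

The source may report more compounds than this note shows. Statements on the series, on what has been measured and on what is new or still open speak of the compounds shown alone.

Of the compounds shown here, two sharing one core have been measured so far. In a functional assay on NCI-H460 cells (Homo sapiens) for cytotoxicity, read by MTT assay, with a stated time of 72 h (a higher number here means a weaker inhibitor, a lower number a stronger inhibitor), compound 1 `CN(C)CCn1cnnc1-c1cc(Oc2ccc(NC(=O)N/N=C/c3ccc(O)c(Br)c3)cc2F)ccn1` gives 430 nM. In this assay compound 2 `CN(C)CCn1cnnc1-c1cc(Oc2ccc(NC(=O)N/N=C/c3cccc(Br)c3)cc2F)ccn1` gives 520 nM. Going by the values given here, the only step on record, a 1.2-fold higher number from compound 1 to compound 2 (0.08 log units; within the scatter), removes a single hydroxy from the aromatic end group, and it stays within the scatter. Compound 2 therefore holds the highest of the two numbers, but its nearest neighbour compound 1 lies within the scatter, so no order between them can be claimed.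

Compound 3 `CN(C)CCn1cnnc1-c1cc(Oc2ccc(NC(=O)N/N=C/c3ccc(O)cc3O)cc2F)ccn1` differs from compound 2 by 2,4-dihydroxyphenyl in place of 3-bromophenyl on a carbon with a double bond to nitrogen. Among the compounds with values here, the single comparable step, from a hydroxy to a hydrogen, changed little, so adding two hydroxy groups and dropping a bromine is expected to move the number only modestly, if at all. Compound 3 is expected to give 450 nM, within a range of 200 nM to 1000 nM. Compound 3 is thus expected to show a 1.2-fold lower number from compound 2 to compound 3 (0.06 log units; within the scatter).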

Compound 3, half-maximal inhibitory concentration: 11300 nM
Compound 3: the middle estimate sits 25-fold (1.40 log units) below what was measured, and the stated range ends below it.
By their numbers in this assay, from the lowest: compounds 1 and 2 (each within the scatter of the next); then compound 3.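

This position is not as forgiving as the earlier pair suggested: on the carbon with a double bond to nitrogen, 2,4-dihydroxyphenyl in place of 3-bromophenyl gives a 22-fold higher number from compound 2 to compound 3 (1.34 log units; beyond the scatter) in this assay. Measured against the 3-bromo-4-hydroxyphenyl group, the same end group gives a 26-fold higher number from compound 1 to compound 3 (1.42 log units; beyond the scatter) and so shows that a hydroxy on this ring is not harmless in every setting, even though compounds 1 and 2 stay within the scatter of each other. No supporting measurement on hand accounts for this jump.

Compound 3 loses the bromine and gains its hydroxy pattern in a single change, so the compounds shown cannot say which of the two carries the rise. A plain phenyl, a 4-hydroxyphenyl or a 3-chlorophenyl end group would help separate these effects.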